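Bis-indole nitrile series: amide aryl group exchange

The source may hold more compounds than are shown below. What is called first, only, known or untested is meant among the compounds shown, and "the series" means these compounds.

Two compounds of this series have numbers in a functional assay on HT-29 cells (Homo sapiens) for cytotoxicity, read by MTT assay, with a stated time of 72 h; on this read-out lower numbers stand for stronger inhibition and higher numbers for weaker inhibition. Compound 1 `CN1[C@@H]2c3[nH]c4ccccc4c3C[C@H]1[C@H](C#N)N1[C@@H](CN3C(=O)c4ccccc4C3=O)c3[nH]c4ccccc4c3C[C@@H]21` gives 80 nM in this assay. Compound 2 `CN1[C@@H]2c3[nH]c4ccccc4c3C[C@H]1[C@H](C#N)N1[C@@H](CNC(=O)c3cccc4c3CCCC4)c3[nH]c4ccccc4c3C[C@@H]21` gives 3340 nM in this assay, the highest of the two numbers, and its gap to compound 1 lies well beyond the scatter. Going by the values given here, no single-point step between measured compounds is available, so the influence of the group on the carbonyl carbon cannot be separated from the rest of the change between compound 1 and compound 2.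

Compound 3 `CN1[C@@H]2c3[nH]c4ccccc4c3C[C@H]1[C@H](C#N)N1[C@@H](CNC(=O)/C=C/c3cccc(C(F)(F)F)c3)c3[nH]c4ccccc4c3C[C@@H]21` is unmeasured. It differs from compound 2 by 2-(3-(trifluoromethyl)phenyl)ethenyl in place of 1,2,3,4-tetrahydronaphthalen-5-yl on a carbonyl carbon. The amide is kept; only the group on the carbonyl carbon changes. On the numbers shown there is no basis for a large step, so the expected step from compound 2 to compound 3 is a 1.7-fold lower number from compound 2 to compound 3 (0.22 log units; within the scatter), a modest move towards lower numbers that may not exceed the scatter. Compound 3 is therefore estimated at 2000 nM in this assay, with a range from 500 nM to 8000 nM.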

Compound 3, half-maximal inhibitory concentration: 5060 nM
Compound 3: middle estimate off by 2.5-fold (0.40 log units), on the low side, within the range that was stated.
By their numbers in this assay, from the lowest: compound 1; then compounds 2 and 3 (each within the scatter of the next).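

Going by these compounds alone, the first single-place reading at this position, the carbonyl carbon of the amide, is that 2-(3-(trifluoromethyl)phenyl)ethenyl in place of 1,2,3,4-tetrahydronaphthalen-5-yl gives a 1.5-fold higher number from compound 2 to compound 3 (0.18 log units; within the scatter) in this assay. The two groups therefore cannot be told apart on this read-out, even though the exchange removes the six-membered non-aromatic ring and brings in a double bond outside aromatic rings and a trifluoromethyl group. No measurement is at hand that explains this outcome.

On these data alone, it remains open whether a group of another kind on the carbonyl carbon, such as a short alkyl chain, a chain ending in an amine or one ending in a carboxylic acid, would move the number beyond the scatter. A single-place link between the amide of compound 2 and the imide-bearing compound 1 is also still missing, so the gap between them stays unassigned.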